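This account rests on a few compounds, and the source may have more. Where it says the series, first, only, none or still open, it means among the compounds named here.

Within the data shown here, compound 1 `Cc1cc(C)c(CN2CCc3c(Cl)cc([C@@H](C)CO)c(Cl)c3C2=O)c(=O)[nH]1` is the only compound with a single reported number in an assay on cells for inhibition of histone-lysine N-methyltransferase EZH2 (Homo sapiens), read by ELISA, with a stated time of 72 h (a lower number here means a stronger inhibitor, a higher number a weaker inhibitor), where compound 1 gives 1040 nM. Compound 2 `COC(C)c1cc(Cl)c2c(c1Cl)C(=O)N(Cc1c(C)cc(C)[nH]c1=O)CC2` has several entries in this assay, giving 1310 nM; 427 nM (2 entries); the spread among those repeats the several entries of compound 2 in this assay, 1310 nM; 427 nM (2 entries) shows how much this assay can wander on its own. Compound 3 `Cc1cc(C)c(CN2CCc3c(Cl)cc([C@H](CO)[C@H]4CCCO4)c(Cl)c3C2=O)c(=O)[nH]1` keeps the shared core and differs from compound 1 in one place: oxolan-2-yl in place of methyl on a saturated chain carbon bound to an aromatic carbon and a saturated chain carbon. Among the measured compounds shown here, no measured pair shows this change, so the move in this assay is expected to be small, a 1.3-fold lower number from compound 1 to compound 3 (0.11 log units; within the scatter), within the usual scatter. Compound 3 is therefore expected to give 800 nM, somewhere between 250 nM and 2500 nM.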

Compound 3, half-maximal inhibitory concentration: 40 nM
Compound 3: middle estimate off by 20-fold (1.30 log units), on the high side; the whole stated range lies above it.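

In this assay, the saturated chain carbon bound to an aromatic carbon and a saturated chain carbon proves sensitive to what it carries: oxolan-2-yl in place of methyl gives a 26-fold lower number from compound 1 to compound 3 (1.41 log units; beyond the scatter). So this place accepts a much larger group, with a ring, and the number still falls. The step also clearly exceeds the wander seen between repeats of a single compound: the several entries of compound 2 in this assay, 1310 nM; 427 nM (2 entries)

Whether the ring, its oxygen or its defined stereocentre accounts for the step stays open. The compounds shown cannot tell how a cyclopentyl group, a longer chain or an amine would behave at this place.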